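A few compounds are considered here, and "the series" means these few. Any claim that something is new, unique, unknown or untested is made for them only; others in the source may bear on it.

Measured compounds:
- compound 1 `CCOc1ccc(C(=O)/C=C/c2ccc(N(C)C)cc2)cc1` with 210 nM in an assay on isolated protein for inhibition of Amine oxidase [flavin-containing] B (Homo sapiens); a higher number here means a weaker inhibitor, a lower number a stronger inhibitor
- compound 2 `CCOc1ccc(C(=O)/C=C/c2ccc(CC)cc2)cc1` with 210 nM in this assay

Compound 2 stands level with compound 1: the step of no change at the digits printed from compound 1 to compound 2 (within the scatter) shows that swapping one para substituent for another left the half-maximal inhibitory concentration unchanged within the usual scatter. Among the compounds with values here, this is the only measured step available, and it bears on the next change only loosely, since it replaced one group with another that carries no hydrogen-bond donor or acceptor.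

Compound 3 `CCOc1ccc(C(=O)/C=C/c2ccc(O)cc2)cc1` is not yet measured. It differs from compound 2 by hydroxy in place of ethyl on an aromatic carbon. The hydroxy group brings one hydrogen-bond donor and one acceptor to a position where compounds 1 and 2 tolerated two rather different groups without any shift in potency. Within the data shown here, no measured step tests a hydroxy at this place, so the expectation rests only on that tolerance. A modest weakening, at most a small step beyond the scatter, is expected: the estimated step of a 1.9-fold higher number from compound 2 to compound 3 (0.28 log units; within the scatter) is small. For compound 3 the expected value is 400 nM, in a range from 100 nM to 1600 nM.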

Compound 3, half-maximal inhibitory concentration: 210 nM
Compound 3: the middle estimate sits 1.9-fold (0.28 log units) above what was measured; the range from low to high includes it.
By their numbers in this assay, from the lowest: compounds 1, 2 and 3 (each within the scatter of the next).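

In this assay, putting hydroxy in place of ethyl gives no change at the digits printed from compound 2 to compound 3 (within the scatter) and so shows that this position, para to a large group, accepts a group with a hydrogen-bond donor and acceptor as readily as ethyl, which has neither. Hydroxy in place of dimethylamino gives no change at the digits printed from compound 1 to compound 3 (within the scatter) as well, so the three groups tested here, which differ in their hydrogen-bonding counts, cannot be told apart by this read-out, and having a donor at this position neither helps nor harms across these compounds. Nothing available explains why the numbers stay level at this position.

As far as these compounds go, whether a carboxylic acid, a primary amine or a longer chain such as butyl would also stay level at this position remains open, and a group of this kind might be what finally moves the number. All three compounds also share the ethoxy group and the rest of the core, so the tolerance seen here says nothing about changes made anywhere else on the molecule.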